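Ethyl to propyl on the chain nitrogen: a small extension

The compounds below may be only part of what the source reports. "The series", "measured", "known", "first", "only" and "open" are said of these compounds alone.

Compound 1, `CCN(Cc1ccccc1)c1nc(C)nc(Nc2ccc(C)cc2)n1`: in an assay on isolated protein for binding affinity to corticotropin-releasing factor receptor 1 (Homo sapiens) (a higher number here means a weaker inhibitor, a lower number a stronger inhibitor), compound 1 gives > 10000 nM, which is a limit of the assay and not a number.
Compound 2, `CCN(Cc1ccccc1)c1nc(C)nc(Nc2c(C)cccc2C)n1`: in this assay compound 2 gives > 10000 nM, again a limit of the assay.

Compound 2 therefore stands at the limit described by the limit of > 10000 nM in this assay, at which 2 of the 2 values shown sit, and it cannot be placed against compound 1, since the step that the two limits leave unreadable from compound 1 to compound 2 is left unreadable by the two limits. The account now follows the change to compound 3, `CCCN(Cc1ccccc1)c1nc(C)nc(Nc2c(C)cccc2C)n1`, which differs from compound 2 by methyl in place of hydrogen on a saturated chain carbon, two bonds along the chain from a nitrogen on an aromatic ring. Going by the values given here, no measured step bears on this change: the only step measured concerns a different part of the molecule and its size is not readable. Nothing therefore points to a change beyond the scatter in this assay, and the expected step that the limit leaves unreadable from compound 2 to compound 3 from compound 2 to compound 3 is close to none. Compound 3 is accordingly estimated at 15000 nM, with a range from 3000 nM to 80000 nM, most likely again reported only as a limit.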

Compound 3, inhibition constant: > 10000 nM
Compound 3: no number, only a limit; the forecaster's own chance of this, stated with the estimate: 80%; the middle value is on the limit's open side.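

Compound 3 gives only a limit of the assay, as do compound 1 and compound 2, so neither step among these compounds can be read: the limit of > 10000 nM in this assay, at which 3 of the 3 values shown sit.

The compounds shown leave open the size and direction of either change, as all three remain without a number.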